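The source may report more compounds than this note shows. Statements on the series, on what has been measured and on what is new or still open speak of the compounds shown alone.

Measured so far in a functional assay on PC-3 cells (Homo sapiens) for cytotoxicity, read by MTT assay, with a stated time of 24 h; a higher number here means a weaker inhibitor, a lower number a stronger inhibitor:
- compound 1, `COc1ccc(-n2cc(COc3c(/C=C\C(=O)O)ccc(OC)c3CC=C(C)C)nn2)cc1`: "not determined" (no result reported)
- compound 2, `COc1ccc(/C=C\C(=O)O)c(OCc2cn(-c3ccccc3)nn2)c1CC=C(C)C`: 35000 nM
- compound 3, `COc1ccc(/C=C\C(=O)O)c(OCc2cn(-c3ccccc3C#N)nn2)c1CC=C(C)C`: "not determined" (no result reported)

The series shares one core and varies only the aryl group on the aromatic nitrogen of the triazole. Compound 2 carries a plain phenyl there and in this assay compound 2 gives 35000 nM, a weak result. Among the compounds with values here, for compound 1 and for compound 3 no number was reported in this assay, so compound 3 stands without a value of its own, and the only number the series offers is that of compound 2.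

The next compound is compound 4, `COc1ccc(/C=C\C(=O)O)c(OCc2cn(-c3ccc(CO)cc3)nn2)c1CC=C(C)C`, which differs from compound 3 in one place: 4-(hydroxymethyl)phenyl in place of 2-cyanophenyl on an aromatic nitrogen. Within the data shown here, no step between two measured compounds is available to calibrate this change, and compound 3 itself has no number, so the step from compound 3 to compound 4 cannot be sized; the expectation rests on compound 2 alone. Since compound 2 gives 35000 nM with a plain phenyl, the expectation for compound 4 is a value in the same weak region, with no shift beyond the usual scatter anticipated. Compound 4 is estimated at 30000 nM, with a plausible range from 10000 nM to 100000 nM.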

Compound 4, half-maximal inhibitory concentration: 28300 nM
For compound 4 the middle estimate is 1.1-fold (0.03 log units) above the measured one; measured number inside the range.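

In this assay, within the data shown here, a 1.2-fold lower number from compound 2 to compound 4 (0.09 log units; within the scatter) is the first readable step, and it lies within the scatter, so hydroxymethyl in place of hydrogen on an aromatic carbon leaves the number where it stood with plain phenyl. At this place on the aryl group attached to the triazole nitrogen, 4-(hydroxymethyl)phenyl therefore reads the same as plain phenyl, and the added hydrogen-bond donor brings no readable gain or loss in cytotoxicity. No measurement on these compounds accounts for this result.

Steps to compound 1 and compound 3 cannot be read, so the aryl groups of those two compounds, including 2-cyanophenyl, remain unsized against either plain phenyl or 4-(hydroxymethyl)phenyl. Also open, from the compounds shown here alone, is whether an amine, a carboxylic acid or a longer chain ending in hydroxyl, carried at the same place on the phenyl ring, would move the number beyond the scatter, since one step within the scatter sets no limit on what this position can accept.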